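Ring nitrogen removed from the carbonyl-bearing aryl group

A few compounds are considered here, and "the series" means these few. Any claim that something is new, unique, unknown or untested is made for them only; others in the source may bear on it.

Three compounds have numbers in a functional assay on MCF7 cells (Homo sapiens) for inhibition, read by sulforhodamine B assay, with a stated time of 72 h; on this read-out lower numbers stand for stronger inhibition and higher numbers for weaker inhibition. Compound 1 `COc1ccc(C(=O)/C=C/c2cn(-c3ccccc3)nc2-c2ccsc2)c(OC)c1OC` gives 7400 nM. Compound 2 `COc1ccc(C(=O)/C=C/c2cn(-c3ccccc3)nc2-c2ccsc2)c(OC)c1` gives 9000 nM. Compound 3 `O=C(/C=C/c1cn(-c2ccccc2)nc1-c1cccnc1)c1ccccn1` gives 4200 nM, the lowest of the three numbers; its gap to compound 1 is within the scatter, while its gap to compound 2 lies beyond it, so compound 3 cannot be set apart from compound 1 on this read-out.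

Compound 4 `O=C(/C=C/c1cn(-c2ccccc2)nc1-c1cccnc1)c1ccccc1` is not yet measured. It differs from compound 3 by phenyl in place of pyridin-2-yl on a carbonyl carbon. For the measured compounds named here, the one measured step in the set, a 1.2-fold higher number from compound 1 to compound 2 (0.09 log units; within the scatter), concerns a methoxy on an aromatic carbon elsewhere in the molecule and lay within the scatter; it does not touch the carbonyl-bearing ring, and compound 3 shares neither of those substitution patterns. Going by the values given here, there is thus no precedent here for swapping pyridin-2-yl for phenyl on the carbonyl carbon, and nothing in the numbers points to a shift beyond the scatter in either direction.

Compound 4 is therefore expected near 5500 nM, with a range from 2500 nM to 13000 nM. The expected step of a 1.3-fold higher number from compound 3 to compound 4 (0.12 log units; within the scatter) stays within the scatter.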

Compound 4, half-maximal inhibitory concentration: 4100 nM
Compound 4: middle estimate off by 1.3-fold (0.13 log units), on the high side; the measured number falls inside the stated range.
By their numbers in this assay, from the lowest: compounds 4, 3, 1 and 2 (each within the scatter of the next, the first and the last beyond it).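

Phenyl in place of pyridin-2-yl on a carbonyl carbon gives, in this assay, a 1.0-fold lower number from compound 3 to compound 4 (0.01 log units; within the scatter), the first step in the series read at this position, since the earlier step concerned a methoxy on an aromatic carbon elsewhere. With this pair, the ring nitrogen and the one hydrogen-bond acceptor counted for pyridin-2-yl can be exchanged for the all-carbon ring of benzoyl with no readable difference, so this read-out does not depend on that nitrogen in the setting of compound 3 and compound 4, and the two six-membered aromatic rings cannot be told apart here. No measurement in hand offers an explanation of why the two aryl groups read alike.

Still open, from the compounds shown here alone, is whether this position tolerates anything other than a six-membered aromatic ring, for instance a saturated cyclohexyl or piperidine ring, or a phenyl carrying an amine or a carboxylic acid. Also open, going by these compounds, is whether the methoxy groups on the benzoyl of compound 1 and compound 2 would read the same on compound 4, as those two compounds differ from it in more than one place.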